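This account rests on a few compounds, and the source may have more. Where it says the series, first, only, none or still open, it means among the compounds named here.

In a physicochemical assay for solubility, in phosphate buffer, at pH 7.4 (a lower number here means a less soluble compound, a higher number a more soluble compound), compound 1 `COc1ccccc1OCCCC1CCOCC1` gives 244000 nM and compound 2 `COc1ccccc1OCCOC1CCOCC1` gives 275000 nM, two values that lie within the scatter of each other. Compound 3 `COc1ccccc1OCCON1CCOCC1` has not yet been measured. It has morpholin-4-yl in place of oxan-4-yl on an oxygen on a saturated carbon. Within the data shown here, no measured pair shows this change, so no step beyond the scatter is expected in this assay. The expected size is a 1.1-fold higher number from compound 2 to compound 3 (0.02 log units; within the scatter). The estimated solubility of compound 3 is 290000 nM, with an expected range of 170000 nM to 480000 nM.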

Compound 3, solubility: 293000 nM
Compound 3: the middle estimate sits 1.0-fold (0.00 log units) below what was measured; low and high end bracket the measured number.
By their numbers in this assay, from the lowest: compounds 1, 2 and 3 (each within the scatter of the next).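

On an oxygen on a saturated carbon, morpholin-4-yl in place of oxan-4-yl gives a 1.1-fold higher number from compound 2 to compound 3 (0.03 log units; within the scatter) in this assay, so this swap of rings separates the two compounds by no more than the scatter. The entering ring carries one more hetero atom and one more hydrogen-bond acceptor than the ring it replaces, and at this position that difference leaves the two values indistinguishable. Nothing available explains this result. Still open, going by these compounds, is whether a charged group at this position, such as a carboxylic acid or a basic amine, or a longer chain, would give a step beyond the scatter in this assay.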